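Swapping the Fused Ring on the Ester Side Chain

The source may hold more compounds than are shown below. What is called first, only, known or untested is meant among the compounds shown, and "the series" means these compounds.

Compound 2 `C=C1C2=C(C(=O)N1OC)[C@H](OC(=O)CSc1nc3ccccc3s1)[C@@](C)(O)[C@H](CCCCC)O2` carries an ester side chain that ends in a sulfur bearing a 1,3-benzothiazol-2-yl group. In a functional assay on K562 cells (Homo sapiens) for cytotoxicity, read by MTT assay, with a stated time of 72 h (a higher number here means a weaker inhibitor, a lower number a stronger inhibitor), compound 2 gives 4300 nM, the lowest of the three numbers shown, although compound 1 sits so close that no order between the two can be claimed. Compound 1 `C=C1C2=C(C(=O)N1OC)[C@H](OC(=O)CSc1nc3ccccc3o1)[C@@](C)(O)[C@H](CCCCC)O2` gives 4500 nM in this assay, and the change a 1.0-fold lower number from compound 1 to compound 2 (0.02 log units; within the scatter). Compound 3 `C=C1C2=C(C(=O)N1OC)[C@H](O)[C@@](C)(O)[C@H](CCCCC)O2`, the shared core without the ester side chain, gives 20000 nM in this assay, a number beyond the scatter above compound 2.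

Compound 4 `C=C1C2=C(C(=O)N1OC)[C@H](OC(=O)CSc1nc3ccccc3[nH]1)[C@@](C)(O)[C@H](CCCCC)O2` differs from compound 2 in one place: 1H-benzimidazol-2-yl in place of 1,3-benzothiazol-2-yl on a sulfur. Among the measured compounds shown here, the only measured step that bears on this kind of exchange of the fused ring is a 1.0-fold lower number from compound 1 to compound 2 (0.02 log units; within the scatter), which left the number essentially unchanged. A similar outcome is expected here, with no step beyond the scatter in either direction; the expected step is a 1.0-fold higher number from compound 2 to compound 4 (0.02 log units; within the scatter). Compound 4 is therefore estimated to give 4500 nM in this assay, with a range from 2000 nM to 10000 nM.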

Compound 4, half-maximal inhibitory concentration: 9300 nM
Estimate against measurement, compound 4: 2.1-fold (0.32 log units) below; the measured number falls inside the stated range.
By their numbers in this assay, from the lowest: compounds 2 and 1 (each within the scatter of the next); then compound 4; then compound 3.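

So the fused ring at this spot is not a free exchange: in this assay, 1H-benzimidazol-2-yl on the sulfur gives a 2.2-fold higher number from compound 2 to compound 4 (0.34 log units; beyond the scatter) and a 2.1-fold higher number from compound 1 to compound 4 (0.32 log units; beyond the scatter), both modest steps but beyond the scatter, whereas the two earlier rings could not be told apart. The entering ring differs from 1,3-benzothiazol-2-yl in its counts, with a hydrogen-bond donor where that group has none, so the position does respond to at least one ring exchange. Nothing shown here measures why the number moved, and no explanation of the step can be drawn from the data.

On these data alone, whether the ring hydrogen on nitrogen matters remains open, and 1-methyl-1H-benzimidazol-2-yl, with a methyl in place of that hydrogen, would test it. Also open, as far as these compounds go, is whether a plain phenyl on the sulfur, without any fused ring, would give a number like these.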